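A few compounds are considered here, and "the series" means these few. Any claim that something is new, unique, unknown or untested is made for them only; others in the source may bear on it.

The compounds measured so far:
- compound 1, `NC(=O)c1c(COc2ccccc2/C=N/NC(=O)c2ccncc2)no[n+]1[O-]`, gives 854000 nM
- compound 2, `CC(C)(C)c1ccc(C(=O)N/N=C/c2ccc3no[n+]([O-])c3c2)cc1`, gives 25200 nM
- compound 3, `NC(=O)c1c(COc2ccc(/C=N/NC(=O)c3ccncc3)cc2)no[n+]1[O-]`, gives 1160000 nM

All three numbers come from an ADME assay on MRC5 cells (Homo sapiens) for cytotoxicity, read by fluorescence, with a stated time of 24 h; on this read-out higher numbers stand for weaker inhibition and lower numbers for stronger inhibition. Among them, compound 2 stands with the lowest number and so is the strongest inhibitor of these cells; its nearest neighbour is compound 1, whose number lies higher by a margin beyond the usual scatter, and compound 3 lies further away still. The two higher numbers belong to compounds built on a different core, so no single change can be read off between them and compound 2.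

Compound 4, `Nc1ccc(C(=O)N/N=C/c2ccc3no[n+]([O-])c3c2)cc1`, has not yet been measured. It differs from compound 2 in one place: amino in place of tert-butyl on an aromatic carbon. For the measured compounds named here, no measured pair shows this same exchange, so the size of the step is open. The expectation is a move toward a higher number, that is weaker inhibition, of modest size, estimated as a 2.4-fold higher number from compound 2 to compound 4 (0.38 log units; beyond the scatter). Compound 4 is therefore expected to give about 60000 nM, within a range from 15000 nM to 250000 nM.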

Compound 4, half-maximal inhibitory concentration: 841000 nM
The estimate for compound 4 lay 14-fold (1.15 log units) below the measured number, outside the stated range (above it).
By their numbers in this assay, from the lowest: compound 2; then compounds 4, 1 and 3 (each within the scatter of the next).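

Replacing tert-butyl with amino on this aromatic carbon, para to a large group, gives a 33-fold higher number from compound 2 to compound 4 (1.52 log units; beyond the scatter) in this assay, which means much weaker inhibition of these cells. This is the first change in a single place among the compounds shown, and it reveals that the group at this carbon can strongly affect the read-out while the rest of the molecule stays the same. No measurement shown here explains the size of this step.

The pair cannot separate the effect of removing tert-butyl from that of adding amino, since both happen in one exchange. Compounds carrying a plain hydrogen, a methyl, a hydroxyl or a dimethylamino group at this carbon would show whether the number follows the size of the group or the presence of nitrogen.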